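Demethylation of an aryl ether in a urea series

The source may hold more compounds than are shown below. What is called first, only, known or untested is meant among the compounds shown, and "the series" means these compounds.

Compound 2, `COc1cc(-c2nn(-c3cccc(NC(=O)Nc4ccc(Cl)c(Cl)c4)c3)cc2-c2ccncc2)ccc1Cl`, 845 nM
Compound 1, `O=C(Nc1cccc(-n2cc(-c3ccncc3)c(-c3ccc(Cl)c(O)c3)n2)c1)Nc1cccc(C(F)(F)F)c1`, 1860 nM

In a functional assay on UO-31 cells (Homo sapiens) for inhibition, read by sulforhodamine B assay, with a stated time of 48 h (on this read-out lower numbers stand for stronger inhibition of growth and higher numbers for weaker inhibition of growth), compound 2 gives 845 nM, the lower of the two numbers, while compound 1 gives 1860 nM. Compound 3, `O=C(Nc1cccc(-n2cc(-c3ccncc3)c(-c3ccc(Cl)c(O)c3)n2)c1)Nc1ccc(Cl)c(Cl)c1`, has not been measured. It differs from compound 2 by hydrogen in place of methyl on an oxygen on an aromatic ring. No single change of this kind has been measured in this series, so the step from compound 2 to compound 3 in this assay is expected to be small, at most a modest weakening not clearly beyond the scatter: a 1.4-fold higher number from compound 2 to compound 3 (0.15 log units; within the scatter). Compound 3 is therefore estimated at 1200 nM, with a range from 450 nM to 3200 nM.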

Compound 3, concentration for 50% growth inhibition: 1250 nM
For compound 3 the middle estimate is 1.0-fold (0.02 log units) below the measured one, and the stated range covers the measured number.
By their numbers in this assay, from the lowest: compounds 2, 3 and 1 (each within the scatter of the next, the first and the last beyond it).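

In this assay, hydroxy in place of methoxy on the aromatic ring gives a small step (a 1.5-fold higher number from compound 2 to compound 3 (0.17 log units; within the scatter)), so at this position the methyl can go without a change that stands clear of the scatter. On the other side of the urea, 3,4-dichlorophenyl in place of 3-(trifluoromethyl)phenyl also gives a small step (a 1.5-fold lower number from compound 1 to compound 3 (0.17 log units; within the scatter)). No supporting evidence accompanies these results to explain either step.

The compounds shown leave open whether this position would accept something larger on the oxygen, such as an ethoxy group, or an amine in place of the hydroxy.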